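The source may report more compounds than this note shows. Statements on the series, on what has been measured and on what is new or still open speak of the compounds shown alone.

Compound 3 `COc1ccc(-c2ccnc(C(=O)N(C)C)c2)cc1S(=O)(=O)Nc1cccc(NCCNC(=O)c2cccc(C)c2)c1` gives 5170 nM in a functional assay on CHO-RD-HGA16 cells for agonist activity at Orexin/Hypocretin receptor type 1 (Homo sapiens), read by fluorescence and calcium flux, with a stated time of 30 min (a higher number here means that more compound is needed for the effect, a lower number that less compound is needed), the higher of the two numbers reported there, and compound 1 `COc1ccc(-c2cccc(C(=O)N(C)C)c2)cc1S(=O)(=O)Nc1cccc(NCCCNC(=O)c2cccc(C)c2)c1` gives 400 nM, a gap that lies beyond the usual scatter. Compound 2 `COc1ccc(-c2cccc(C(=O)N(C)C)c2)cc1S(=O)(=O)Nc1cccc(N2CCN(C(=O)c3cccc(C)c3)CC2)c1` reaches only the limit of this assay at > 10000 nM. Compound 4 `COc1ccc(-c2csc(C(=O)N(C)C)c2)cc1S(=O)(=O)Nc1cccc(NCCNC(=O)c2cccc(C)c2)c1` differs from compound 3 by 5-(dimethylcarbamoyl)thiophen-3-yl in place of 2-(dimethylcarbamoyl)pyridin-4-yl on an aromatic carbon. Going by the values given here, no measured pair covers this exchange on its own, so the direction remains open. The step of a 2.1-fold lower number from compound 3 to compound 4 (0.32 log units; beyond the scatter) is expected to be modest, tending toward a lower number but not certainly beyond the scatter. Compound 4 is therefore estimated at 2500 nM, with a likely range from 800 nM to 8000 nM.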

Compound 4, half-maximal effective concentration: 1330 nM
Compound 4: the middle estimate sits 1.9-fold (0.27 log units) above what was measured; low and high end bracket the measured number.
By their numbers in this assay, from the lowest: compound 1; then compound 4; then compound 3. At a limit, above all of these: compound 2.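

In this assay, this position responds to the ring that carries the dimethylcarbamoyl group: 5-(dimethylcarbamoyl)thiophen-3-yl in place of 2-(dimethylcarbamoyl)pyridin-4-yl gives a 3.9-fold lower number from compound 3 to compound 4 (0.59 log units; beyond the scatter). This is the first exchange in a single place among the compounds shown, and it sits on the aromatic carbon para to a methoxy group. No measured property shown bears on this step.

The compounds shown leave open what a carboxylic acid or a primary amide in place of the dimethylcarbamoyl group would do here. They also do not separate the effect of this ring from that of the chain, as both change together between compound 1 and compound 4.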